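The source may hold more compounds than are shown below. What is called first, only, known or untested is meant among the compounds shown, and "the series" means these compounds.

Measured in an assay on CHO cells for displacement of a labelled ligand from 5-hydroxytryptamine receptor 1B (Homo sapiens); on this read-out lower numbers stand for stronger inhibition and higher numbers for weaker inhibition:
compound 1, `c1ccc2c(c1)CCC2NC1CCN(CCCc2c[nH]c3ccc(-n4cnnc4)cc23)CC1`: 280 nM
compound 2, `CN(Cc1ccsc1)C1CCN(CCCc2c[nH]c3ccc(-n4cnnc4)cc23)CC1`: 35 nM
compound 3, `CC(=O)Nc1ccc(CNCC2CCN(CCCc3c[nH]c4ccc(-n5cnnc5)cc34)CC2)cc1`: 8.9 nM

Compound 3 gives the lowest number of the three; compound 2 sits nearest to it at a gap beyond the scatter, and compound 1 lies furthest. Among the measured compounds shown here, the only step between neighbours, an 8.0-fold lower number from compound 1 to compound 2 (0.90 log units; beyond the scatter), concerns a change on a saturated ring carbon and does not touch the amine nitrogen that is varied next, so it offers no direct read on the change below.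

Compound 4, `C[C@H](NCC1CCN(CCCc2c[nH]c3ccc(-n4cnnc4)cc23)CC1)c1ccccc1`, differs from compound 3 by 1-phenylethyl in place of 4-acetamidobenzyl on an amine nitrogen. The entering group carries no hydrogen-bond donor or acceptor where the leaving group carried one of each, and it brings a defined stereocentre. For the measured compounds named here, no measured pair in this set isolates that change, so the expectation rests on the value of compound 3 alone, with wide uncertainty. A modest rise in number is expected, a 2.8-fold higher number from compound 3 to compound 4 (0.45 log units; beyond the scatter). Compound 4 is estimated at 25 nM in this assay, with a range from 7 nM to 90 nM.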

Compound 4, half-maximal inhibitory concentration: 58 nM
The estimate for compound 4 lay 2.3-fold (0.37 log units) below the measured number; low and high end bracket the measured number.
By their numbers in this assay, from the lowest: compound 3; then compounds 2 and 4 (each within the scatter of the next); then compound 1.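

In this assay, the amine nitrogen proves sensitive to its substituent: a 6.5-fold higher number from compound 3 to compound 4 (0.81 log units; beyond the scatter), although the swap removes the acetamide and adds a defined stereocentre together, so neither can be credited alone. Against the other side chains on the saturated ring carbon, a 1.7-fold higher number from compound 2 to compound 4 (0.22 log units; within the scatter), while a 4.8-fold lower number from compound 1 to compound 4 (0.68 log units; beyond the scatter), so compound 4 remains clear of the indanyl amine but cannot be ranked against the thiophene amine. Nothing available explains the loss on leaving 4-acetamidobenzyl.

Still open, on these data alone, is whether the acetamide or the branching methyl governs this step, a question that plain benzyl and 4-acetamido-1-phenylethyl on the same nitrogen could separate. The opposite enantiomer of the 1-phenylethyl group would give the first read on the stereocentre.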